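Ester for hydroxymethyl on the shared core: expected potency

The compounds below may be only part of what the source reports. "The series", "measured", "known", "first", "only" and "open" are said of these compounds alone.

Measured so far in an ADME assay on cells for inhibition of Amine oxidase [flavin-containing] A (Homo sapiens), read by spectrophotometry; a lower number here means a stronger inhibitor, a higher number a weaker inhibitor:
Compound 1, `S=C(Nc1ccccc1)Nc1ccc2[nH]ccc2c1`: compound 1 gives > 30000 nM, which is a limit of the assay and not a number.
Compound 2, `OCc1ccc(NC(=S)Nc2ccc3[nH]ccc3c2)cc1`: compound 2 is reported as "not active" (no number reported) in this assay, with no number attached.
Compound 3, `CC(=O)c1ccc(NC(=S)Nc2ccc3[nH]ccc3c2)cc1`: compound 3 gives 67000 nM in this assay.
Compound 4, `CCOC(=O)c1ccc(NC(=S)Nc2ccc3[nH]ccc3c2)cc1`: not yet measured in this assay.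

Compound 2 therefore stands nowhere on a scale: it carries no number, and of the values shown one further entry is a limit rather than a number, namely that of compound 1 (the limit of > 30000 nM in this assay, at which 1 of the 3 values shown sits). Among the measured compounds shown here, the only readable number in the set is the weak one of compound 3.

The change from compound 2 to compound 4 is ethoxycarbonyl in place of hydroxymethyl on an aromatic carbon. For the measured compounds named here, the one measured step that touches the same aromatic carbon is a step that the limit leaves unreadable from compound 1 to compound 3, which cannot be read because the value of compound 1 is a limit (the limit of > 30000 nM in this assay, at which 1 of the 3 values shown sits). Going by the values given here, no measured step therefore gives a size or direction for the change from compound 2 to compound 4 in this assay; the expectation rests only on the weak values of the whole set.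

Compound 4 is expected to remain weak in this assay, estimated at 60000 nM, with a range of 20000 nM to 200000 nM, and a real chance that only a limit is reported.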

Compound 4, half-maximal inhibitory concentration: 71000 nM
Estimate against measurement, compound 4: 1.2-fold (0.07 log units) below; the range from low to high includes it.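

In this assay, ethoxy in place of methyl on the carbonyl carbon gives a 1.1-fold higher number from compound 3 to compound 4 (0.03 log units; within the scatter), so acetyl and ethoxycarbonyl cannot be told apart at this position. Compound 2, with hydroxymethyl on the same aromatic carbon, is reported as "not active" (no number reported), whereas compound 4 carries a number, so ethoxycarbonyl gives a readable though weak value where hydroxymethyl gives none. Compound 1 gives > 30000 nM, which is a limit and not a number, so the steps from compound 1 cannot be read and the effect of either carbonyl group against hydrogen stays unknown: the limit of > 30000 nM in this assay, at which 1 of the 4 values shown sits.

Going by these compounds, whether a carboxylic acid or an amine at this position would give a value clearly apart from these weak ones remains open. So does whether any change on the shared core itself would do so.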